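Swapping the aryl group on compound 3

The compounds below may be only part of what the source reports. "The series", "measured", "known", "first", "only" and "open" are said of these compounds alone.

Results so far in a functional assay on MCF7 cells (Homo sapiens) for antiproliferative activity, read by MTT assay; a higher number here means a weaker inhibitor, a lower number a stronger inhibitor:
Compound 1 `COc1ccc(-n2cc(COc3ccc(/C=C/C(=O)c4cc5c(cc4O)OC(C)(C)CC5)cc3)nn2)c([N+](=O)[O-])c1`: "not active" (no number reported)
Compound 2 `CC(=O)c1ccc(-n2cc(COc3ccc(/C=C/C(=O)c4cc5c(cc4O)OC(C)(C)CC5)cc3)nn2)cc1`: 182000 nM
Compound 3 `CC1(C)CCc2c(ccc(C(=O)/C=C/c3ccc(OCc4cn(-c5ccc(Cl)cc5)nn4)cc3)c2O)O1`: "not active" (no number reported)

Compound 3 has no single number to its name. In this assay compound 3 is reported as "not active" (no number reported), and compound 1 is the one other entry of that kind. Compound 2 alone gives a figure, and that figure is a high one on a scale where higher means weaker.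

The next compound is compound 4 `COc1ccc(-n2cc(COc3ccc(/C=C/C(=O)c4ccc5c(c4O)CCC(C)(C)O5)cc3)nn2)c([N+](=O)[O-])c1`, which keeps the core of compound 3 and changes one group: 4-methoxy-2-nitrophenyl in place of 4-chlorophenyl on an aromatic nitrogen. In words, 4-methoxy-2-nitrophenyl stands in place of 4-chlorophenyl on an aromatic nitrogen. Compound 1 carries the same 4-methoxy-2-nitrophenyl on its own core and is reported as "not active" (no number reported).

For the measured compounds named here, no measured step between two compounds is available, so the size of this change cannot be read from the data. The expectation is for no shift beyond the scatter in this assay, with compound 4 remaining in the weak range set by compound 2 at 182000 nM. A report with no number would be quite likely. If a number is obtained, compound 4 is expected to give about 150000 nM, within an estimated range of 40000 nM to 400000 nM.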

Compound 4, half-maximal inhibitory concentration: 73100 nM
Estimate against measurement, compound 4: 2.1-fold (0.31 log units) above; the measured number falls inside the stated range.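

In this assay, for the compounds shown here, compound 3 is reported as "not active" (no number reported) while compound 4 gives 73100 nM so no step between these two compounds can be read. The compounds shown leave open how much swapping the group on the aromatic nitrogen shifts activity on a single core. No supporting evidence bears on this result.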